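The source may report more compounds than this note shows. Statements on the series, on what has been measured and on what is new or still open speak of the compounds shown alone.

Measured so far:
compound 1 `O=C(CCCc1ccc2cccnc2n1)NCc1cc(-c2ccc(F)c(Cl)c2)no1` gives 90 nM
compound 2 `O=C(CCCc1ccc2cccnc2n1)NCc1cc(-c2ccc(F)c(C(F)(F)F)c2)no1` gives 35 nM
compound 3 `FC(F)(F)c1ccc(-c2nnc(CCCCc3ccc4cccnc4n3)o2)cc1` gives 3000 nM

All three were tested in a functional assay on CHO-K1 cells for antagonist activity at succinate receptor 1 (Homo sapiens), read by FLIPR and calcium flux; on this read-out lower numbers stand for stronger inhibition and higher numbers for weaker inhibition. Compound 2 and compound 1 share one core and differ in a single place, (chloro in place of trifluoromethyl on an aromatic carbon). That change made a step of a 2.6-fold higher number from compound 2 to compound 1 (0.41 log units; beyond the scatter). Compound 3 has a different core, and the difference between the two cores is not broken down here; in this assay compound 3 gives 3000 nM, the highest of the three numbers.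

Compound 4 `Clc1ccc(-c2nnc(CCCCc3ccc4cccnc4n3)o2)cc1` has not been measured yet. It is derived from compound 3 by chloro in place of trifluoromethyl on an aromatic carbon. For the measured compounds named here, this is the same kind of change as the one from compound 2 to compound 1, but the surroundings differ: in the measured pair the place is ortho to a fluoro group and meta to a large group, while in compound 4 it is para to a large group. Starting from compound 3, the number for compound 4 is expected to move by about a 2.3-fold higher number from compound 3 to compound 4 (0.37 log units; beyond the scatter), resting on the one earlier step of a 2.6-fold higher number from compound 2 to compound 1 (0.41 log units; beyond the scatter) as the only guide. The estimate for compound 4 in this assay is therefore 7000 nM, with a range from 2500 nM to 20000 nM.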

Compound 4, half-maximal inhibitory concentration: > 3000 nM
Compound 4: no number, only a limit (the forecaster's own chance of this, stated with the estimate: 25%); the middle value is on the limit's open side.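

In this assay compound 4 gives > 3000 nM, which is a limit of the assay and not a number. This shows only that putting chloro in place of trifluoromethyl made a step of a number no lower from compound 3 to compound 4 (the limit leaves the size open), which points the same way as the earlier step on the other core. It does not show whether the change carries over at the same size, since the size of the new step cannot be read, and so the two steps cannot be compared: the same change on two cores in this assay, a 2.6-fold higher number (0.41 log units; beyond the scatter) from compound 2 to compound 1 and a number no lower (the limit leaves the size open) from compound 3 to compound 4; the limit leaves it open whether they differ

The compounds shown leave open how a nitrile, a methoxy group or a plain hydrogen in this place would fare on either core. They also leave open whether the fluoro group carried by compound 1 and compound 2 would make any difference on the core of compound 3.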